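Amine substitution on the benzamide: compound 3 to compound 4

The compounds below may be only part of what the source reports. "The series", "measured", "known", "first", "only" and "open" are said of these compounds alone.

Series on the shared core of compound 1 `CC(C)CCN(CCC(C)C)c1ccc(C(=O)N2CCc3ccc(OS(N)(=O)=O)cc3C2)cc1`, varied at the amino group on the benzamide ring, read in an assay on HEK293 cells for inhibition of Steryl-sulfatase (Homo sapiens), tested at 1 uM; a lower number here means a weaker effect, a higher number a stronger effect of the compound at the concentration tested. Compound 1 gives 90.8%; compound 2 `NS(=O)(=O)Oc1ccc2c(c1)CN(C(=O)c1ccc(N3CCCCC3)cc1)CC2` gives 38.3%; compound 3 `CCN(Cc1ccccc1)c1ccc(C(=O)N2CCc3ccc(OS(N)(=O)=O)cc3C2)cc1` gives 83.6%, the second highest of the three numbers, close to compound 1 and far from compound 2.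

Steps: a number 7.2 percentage points lower from compound 1 to compound 3 (within the scatter); a number 52.5 percentage points lower from compound 1 to compound 2 (beyond the scatter); a number 45.3 percentage points higher from compound 2 to compound 3 (beyond the scatter).

Compound 4 `CCCN(Cc1ccccc1)c1ccc(C(=O)N2CCc3ccc(OS(N)(=O)=O)cc3C2)cc1` differs from compound 3 by methyl in place of hydrogen on a saturated chain carbon, two bonds along the chain from a nitrogen on an aromatic ring. Among the compounds with values here, the one step that bears on it, a number 7.2 percentage points lower from compound 1 to compound 3 (within the scatter), shows that a larger change at this amine left the read-out within the scatter, so no step beyond the scatter is expected here. The step from compound 3 to compound 4 is estimated at a number 1.4 percentage points higher from compound 3 to compound 4 (within the scatter). For compound 4 the expected value is 85%, in the range 72% to 94%.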

Compound 4, a percentage reported as inhibition, at one concentration (the size of the read-out at that concentration, not a potency): 94.3%
Compound 4: the middle estimate sits 9.3 percentage points below what was measured; the measured number lies above the stated range.
By their numbers in this assay, from the lowest: compound 2; then compounds 3, 1 and 4 (each within the scatter of the next, the first and the last beyond it).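

In this assay, a change as small as ethyl to propyl on the benzyl-bearing amine moves the read-out (a number 10.7 percentage points higher from compound 3 to compound 4 (beyond the scatter)). Benzyl(propyl)amino stands level with diisopentylamino (a number 3.5 percentage points higher from compound 1 to compound 4 (within the scatter)) and remains far from piperidin-1-yl (a number 56 percentage points higher from compound 2 to compound 4 (beyond the scatter)). Nothing available accounts for these steps.

Going by these compounds, whether a butyl chain in place of propyl keeps the read-out at this level remains open. So does whether a pyrrolidin-1-yl or morpholin-4-yl ring in place of piperidin-1-yl falls as low as compound 2.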